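Trimming the Amide Cap: Nitrophenyl Gives Way to Methoxymethyl

The source may report more compounds than this note shows. Statements on the series, on what has been measured and on what is new or still open speak of the compounds shown alone.

Of the compounds shown here, two built on one shared core have been tested in a functional assay on KBVIN cells (Homo sapiens) for antiproliferative activity, read by sulforhodamine B assay, with a stated time of 3 days; a lower number here means a stronger inhibitor of growth, a higher number a weaker inhibitor of growth. Compound 1 `O=C(Nc1ccc(C(F)(F)F)cc1)c1cccc(Nc2ncc(F)c(Nc3ccc(F)cc3)n2)c1` reaches only a limit of this assay, reported as > 10000 nM; that reading is a limit rather than a measured number, as the summary the limit of > 10000 nM in this assay, at which 1 of the 2 values shown sits, records. Among the measured compounds shown here, compound 2 `O=C(Nc1cccc(Nc2ncc(F)c(Nc3ccc(F)cc3)n2)c1)c1cccc([N+](=O)[O-])c1` is the only compound with a measured number, and in this assay compound 2 gives 11400 nM, which places it among weak inhibitors of growth. For the measured compounds named here, since only one number exists, no step between measured compounds can be drawn, and no trend in either direction is established.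

Compound 3 `COCC(=O)Nc1cccc(Nc2ncc(F)c(Nc3ccc(F)cc3)n2)c1` differs from compound 2 in a single place: methoxymethyl in place of 3-nitrophenyl on a carbonyl carbon. The carbonyl carbon keeps its amide-type nitrogen neighbour, so only the cap on the amide changes.

With nothing to anchor the change, the expected step from compound 2 to compound 3 in this assay is a 1.3-fold higher number from compound 2 to compound 3 (0.12 log units; within the scatter), small and most likely within the scatter, leaning if anything toward weaker inhibition. Compound 3 is therefore estimated at 15000 nM, with a plausible range from 4000 nM to 50000 nM, and a real chance that this assay again reports only a limit.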

Compound 3, concentration for 50% growth inhibition: 3940 nM
Beside the measured number, compound 3's estimate is 3.8-fold (0.58 log units) above it; the whole stated range lies above it.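

In this assay, among the compounds shown here, the cap on the amide turns out to matter: putting methoxymethyl in place of 3-nitrophenyl on a carbonyl carbon gives a 2.9-fold lower number from compound 2 to compound 3 (0.46 log units; beyond the scatter), the first readable step and one that lies beyond the usual scatter. It also shows that a ring in the cap is not required for this level of growth inhibition, since methoxymethyl, with no ring and 3 heavy atoms against 9, gives the lower number, although the gain is modest. For the compounds shown here, nothing measured so far explains why the smaller cap gives the lower number.

This single step cannot separate the loss of the aromatic ring from the loss of the nitro group or the arrival of the ether oxygen, and a plain phenyl cap or a simple ethyl cap on the same carbonyl carbon would be needed to pull these apart. On these data alone, whether a longer chain, an amine or a carboxylic acid at this place would lower the number further, or raise it again, also remains open.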